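The compounds below may be only part of what the source reports. "The series", "measured", "known", "first", "only" and "open" are said of these compounds alone.

Compound 1 `COc1ccc(C2N=C(SCc3ccccc3)NC(C)=C2C(=O)Nc2ccc(F)cc2)cc1OC` gives 3.1% in a functional assay on the whole organism (artery, strain albino) with Rattus norvegicus as the target, with a stated time of 600 min, at a dose of 10 mg/kg by the oral route; a lower number here means less inhibition, a higher number more inhibition at the dose given (going by the name of the read-out). Compound 2 `COc1ccc(C2N=C(SCc3cccc(Cl)c3)NC(C)=C2C(=O)Nc2ccc(F)cc2)cc1OC` gives 17.4% in this assay. Compound 3 `CC1=C(C(=O)Nc2ccc(F)cc2)C(c2ccc([N+](=O)[O-])cc2)N=C(SCc2ccccc2)N1` gives 32.3% in this assay.

Compound 3 stands highest of the three numbers; its value lies beyond the scatter above that of compound 2, and the step of a number 29.2 percentage points higher from compound 1 to compound 3 (beyond the scatter) shows how far it lies above compound 1. Compound 4 `CC1=C(C(=O)Nc2ccc(F)cc2)C(c2ccc([N+](=O)[O-])cc2)N=C(SCc2ccc(Cl)cc2)N1` differs from compound 3 in one place: chloro in place of hydrogen on an aromatic carbon. A change of the same kind has been measured once, as a number 14.3 percentage points higher from compound 1 to compound 2 (beyond the scatter), where the chlorine also enters an aromatic ring of the benzylsulfanyl group, though at a different point of that ring. For the measured compounds named here, that single step was modest and upward, and it is the only guide here; the two changes do not sit at the same point, so the size carries some doubt. A modest upward step in this assay is therefore expected for compound 4. Compound 4 is expected to give 45%, with a range from 28% to 62%. The expected step is a number 12.7 percentage points higher from compound 3 to compound 4 (beyond the scatter).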

Compound 4, a percentage reported as inhibition, in the whole organism at one dose (the size of the read-out at that dose, not a potency): 28.2%
The estimate for compound 4 lay 16.8 percentage points above the measured number; the range from low to high includes it.
By their numbers in this assay, from the lowest: compound 1; then compound 2; then compounds 4 and 3 (each within the scatter of the next).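

In this assay, the 4-chlorobenzyl group of compound 4 brings no clear change over the benzyl group of compound 3: a number 4.1 percentage points lower from compound 3 to compound 4 (within the scatter). The chloro step measured earlier therefore does not carry over as a general rule for this change: the same change on two cores in this assay, a number 14.3 percentage points higher (beyond the scatter) from compound 1 to compound 2 and a number 4.1 percentage points lower (within the scatter) from compound 3 to compound 4, 18.4 percentage points apart, beyond the scatter of two such steps The two steps differ both in where chloro sits on the benzyl ring and in the group on the saturated ring carbon, 3,4-dimethoxyphenyl or 4-nitrophenyl, and these compounds cannot separate those two differences.

A 4-chlorobenzyl group on the core of compound 1 would be the direct test of which difference matters. Going by these compounds, how an amine or a carboxylic acid at this same ring position would read in this assay remains open.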